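The compounds below may be only part of what the source reports. "The series", "measured", "known", "first", "only" and "open" are said of these compounds alone.

Compound 1 `CCCCCCCCNC(=O)[C@@H](NC(=O)c1cccs1)[C@@H](C)O`: 91900 nM
Compound 2 `CCCCCCCCCCCCNC(=O)[C@@H](NC(=O)c1cccs1)[C@@H](C)O`: 23900 nM
Compound 3 `CCCCCCCCCCCCCCNC(=O)[C@@H](NC(=O)c1cccs1)[C@@H](C)O`: 63000 nM

In a functional assay on SiHa cells (Homo sapiens) for cytotoxicity, read by MTT assay, with a stated time of 48 h (a higher number here means a weaker inhibitor, a lower number a stronger inhibitor), compound 3 gives 63000 nM, the second highest of the three numbers; it sits close to compound 1 and clearly apart from compound 2, since the step of a 2.6-fold higher number from compound 2 to compound 3 (0.42 log units; beyond the scatter) lies beyond the scatter. Compound 4 `CCCCCCCCCCCCCCNC(=O)[C@@H](NC(=O)/C=C/c1ccccc1)[C@@H](C)O` differs from compound 3 in one place: 2-phenylethenyl in place of thiophen-2-yl on a carbonyl carbon. For the measured compounds named here, none of the measured steps touches this part of the molecule; the steps of a 3.8-fold lower number from compound 1 to compound 2 (0.58 log units; beyond the scatter) and a 1.5-fold lower number from compound 1 to compound 3 (0.16 log units; within the scatter) concern only the length of the alkyl chain. There is thus no direct guide for this change, and the expected step of a 1.3-fold lower number from compound 3 to compound 4 (0.10 log units; within the scatter) is small, within the scatter. Compound 4 is therefore estimated at 50000 nM, in a range from 15000 nM to 150000 nM.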

Compound 4, half-maximal inhibitory concentration: 35800 nM
Compound 4: middle estimate off by 1.4-fold (0.15 log units), on the high side, and the stated range covers the measured number.
By their numbers in this assay, from the lowest: compounds 2, 4, 3 and 1 (each within the scatter of the next, the first and the last beyond it).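

This is the first change shown on the carbonyl side of the molecule rather than in the alkyl chain. In this assay, putting 2-phenylethenyl in place of thiophen-2-yl on this carbonyl carbon gives a 1.8-fold lower number from compound 3 to compound 4 (0.25 log units; within the scatter), so swapping the sulfur-containing ring for a larger, all-carbon group leaves the number within the usual spread. Nothing available explains this result. Still open, going by these compounds, is whether an amine or a carboxylic acid at this place would shift the number beyond the scatter, and whether 2-phenylethenyl would behave the same way on the shorter chain of compound 2.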